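A Methyl Added to the Core of Compound 1

This account rests on a few compounds, and the source may have more. Where it says the series, first, only, none or still open, it means among the compounds named here.

For the measured compounds named here, compound 1 `C=CCNc1nc(NCc2ccc(C(=O)Nc3ccc(F)cc3)cc2)c2ccccc2n1` is one of three compounds measured in a functional assay on HCT-116 cells (Homo sapiens) for inhibition, read by luminescence and resazurin assay, with a stated time of 3 days (a higher number here means a weaker inhibitor, a lower number a stronger inhibitor), and in that assay compound 1 gives 14000 nM. Compound 3 `CN(C)c1nc(NCc2ccc(NC(=O)c3ccncc3)cc2)c2ccccc2n1` gives 15000 nM in this assay; the two numbers lie within the scatter of each other, so compound 1 and compound 3 cannot be told apart, even though compound 1 holds the smaller of the two numbers reported as numbers. Compound 2 `CNc1nc2ccccc2c(NCc2ccc(NC(=O)c3ccc(F)cc3)cc2)c1C#N` reaches only a limit of the measurement, (the limit of > 20000 nM in this assay, at which 1 of the 3 values shown sits), and its result in this assay is recorded as > 20000 nM.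

Compound 4 `C=CCNc1nc(NCc2ccc(C(=O)Nc3ccc(F)cc3)cc2)c2cc(C)ccc2n1` differs from compound 1 in one place: methyl in place of hydrogen on an aromatic carbon. Going by the values given here, no pair of measured compounds that differ in a single place is available here, so the size of this step cannot be read from the data and must be expected instead. A change of this size is expected to move the number little, if at all, and a step of a 1.2-fold lower number from compound 1 to compound 4 (0.07 log units; within the scatter) is estimated, within the scatter. Compound 4 is therefore expected to give about 12000 nM in this assay, with a range from 5000 nM to 30000 nM.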

Compound 4, half-maximal inhibitory concentration: 13000 nM
Compound 4: the middle estimate sits 1.1-fold (0.03 log units) below what was measured; the range from low to high includes it.
By their numbers in this assay, from the lowest: compounds 4, 1 and 3 (each within the scatter of the next). At a limit, above all of these: compound 2.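

For the compounds shown here, compound 4 gives the first step in this set between measured compounds that differ in one place: in this assay, methyl in place of hydrogen on an aromatic carbon amounts to a 1.1-fold lower number from compound 1 to compound 4 (0.03 log units; within the scatter). The earlier compounds shown here differ from one another in more than one place, so they could say nothing about this position, whereas this pair shows that the number does not respond measurably when this single carbon of the fused system carries a methyl rather than a hydrogen. Nothing in the data on hand accounts for this result.

What the compounds shown leave open is whether anything other than methyl at this same aromatic carbon, such as an amine, a carboxylic acid, a methoxy group or a longer chain, would produce a step beyond the scatter, since one small group cannot show how much room for change this position allows. From the compounds shown here alone, it also remains open whether methyl on other aromatic carbons of the shared core, or the same methyl on compound 3, would behave as it does here.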